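The source may report more compounds than this note shows. Statements on the series, on what has been measured and on what is new or still open speak of the compounds shown alone.

Working notes on the series.

Three compounds carry the shared core of compound 1 `COc1cc(Cl)cc(-c2nn(-c3cccc(NC(=O)c4ccc(Cl)c(Cl)c4)c3)cc2-c2ccncc2)c1` and have been measured in a functional assay on MDA-MB-231 cells (Homo sapiens) for inhibition, read by sulforhodamine B assay, with a stated time of 48 h, tested at 10 uM; on this read-out lower numbers stand for a stronger effect and higher numbers for a weaker effect at the one concentration tested. In this assay compound 1 gives 33.9%. Compound 2 `COc1cc(Cl)cc(-c2nn(-c3cccc(NC(=O)Nc4ccc(Cl)c(C(F)(F)F)c4)c3)cc2-c2ccncc2)c1` gives -30.8% in this assay, and compound 3 `COc1cc(Cl)cc(-c2nn(-c3cccc(NC(=O)Nc4cccc(C(F)(F)F)c4)c3)cc2-c2ccncc2)c1` gives -9.21% there. Among the three, compound 3 stands second highest: compound 2 lies nearest, and a number 21.6 percentage points higher from compound 2 to compound 3 (beyond the scatter); compound 1 lies furthest, and a number 43.1 percentage points lower from compound 1 to compound 3 (beyond the scatter).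

Compound 4 `COc1cc(Cl)cc(-c2nn(-c3cccc(NC(=O)c4cccc(C(F)(F)F)c4)c3)cc2-c2ccncc2)c1` is not yet measured in this assay. It differs from compound 3 in one place: 3-(trifluoromethyl)phenyl in place of (3-(trifluoromethyl)phenyl)amino on a carbonyl carbon. Going by the values given here, no measured step isolates this exchange of an (3-(trifluoromethyl)phenyl)amino for a 3-(trifluoromethyl)phenyl on the carbonyl carbon. Among the compounds with values here, the nearest analogues are the steps from the one carbonyl-aryl compound to the two carbonyl-amino compounds, where a number 64.7 percentage points lower from compound 1 to compound 2 (beyond the scatter) and a number 43.1 percentage points lower from compound 1 to compound 3 (beyond the scatter), though both of those steps also change the aryl substituents, and the substituent-only step a number 21.6 percentage points higher from compound 2 to compound 3 (beyond the scatter) is modest by comparison. Taken together, the move from compound 3 to compound 4 is therefore expected to run upward in this assay by roughly a number 29.2 percentage points higher from compound 3 to compound 4 (beyond the scatter). For compound 4 in this assay the expected value is 20%, within a range of -5% to 45%.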

Compound 4, a percentage reported as activity, at one concentration (the size of the read-out at that concentration, not a potency): 21.4%
The estimate for compound 4 lay 1.4 percentage points below the measured number; low and high end bracket the measured number.
By their numbers in this assay, from the lowest: compound 2; then compound 3; then compound 4; then compound 1.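

With the 3-(trifluoromethyl)phenyl group held constant, the change on the carbonyl carbon is now isolated in this assay, and the step is large: a number 30.6 percentage points higher from compound 3 to compound 4 (beyond the scatter) on loss of the amino link alone. The other two steps change more than one feature of the group on the carbonyl carbon: a number 52.2 percentage points higher from compound 2 to compound 4 (beyond the scatter) also loses the chloro and is large, while a number 12.5 percentage points lower from compound 1 to compound 4 (beyond the scatter) keeps the aryl group on the carbonyl carbon, exchanges only its substituents and is modest. Among the four compounds, the two with the aryl group on the carbonyl carbon, compound 1 and compound 4, both stand above the two with the amino link, compound 2 and compound 3, and none goes against this split.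

Still open, as far as these compounds go, is whether a methylamino or a methylene link on the carbonyl carbon would track the amino link or the aryl compounds. Also open, from the compounds shown here alone, is whether adding a chloro to compound 4 would repeat the step seen between the two amino-linked compounds, and nothing at hand accounts for the size of the change at this position.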